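A few compounds are considered here, and "the series" means these few. Any claim that something is new, unique, unknown or untested is made for them only; others in the source may bear on it.

In an ADME assay for pharmacokinetics (on this read-out higher numbers stand for a longer-lived compound and lower numbers for a shorter-lived compound), compound 2 `NC(=O)c1ncn2c(=O)n(-c3ccccc3)nnc12` gives 0.15 h and compound 1 `CCOc1ccc(-n2nnc3c(C(N)=O)ncn3c2=O)cc1` gives 0.133 h, so the two stand level within the usual scatter. Compound 3 `Cc1ccc(-n2nnc3c(C(N)=O)ncn3c2=O)cc1` is compound 2 with a single change, methyl in place of hydrogen on an aromatic carbon. Within the data shown here, the one measured step that bears on this also swaps a group for hydrogen on an aromatic carbon, and it was small: a 1.1-fold higher number from compound 1 to compound 2 (0.05 log units; within the scatter). No step beyond the scatter is therefore expected in this assay, and the expected step is a 1.1-fold lower number from compound 2 to compound 3 (0.03 log units; within the scatter). Compound 3 is estimated at 0.14 h, with an expected range of 0.08 h to 0.25 h.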

Compound 3, half-life: 0.125 h
Compound 3: middle estimate off by 1.1-fold (0.05 log units), on the high side, and the stated range covers the measured number.
By their numbers in this assay, from the lowest: compounds 3, 1 and 2 (each within the scatter of the next).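

In this assay, the position on the six-membered aromatic ring, para to a large group, now has a small carbon group as well as hydrogen and ethoxy: a 1.2-fold lower number from compound 2 to compound 3 (0.08 log units; within the scatter) for methyl against hydrogen, and a 1.1-fold lower number from compound 1 to compound 3 (0.03 log units; within the scatter) for methyl against ethoxy. So all three groups stand level at this position, and adding methyl to the ring does not separate compound 3 from the other two. No measurement here explains this level result. Still open, going by these compounds, is whether an amine, a carboxylic acid or a longer chain at this position would give a step beyond the scatter.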